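The source may report more compounds than this note shows. Statements on the series, on what has been measured and on what is new or still open speak of the compounds shown alone.

Measured compounds:
- compound 1, `Cc1ccccc1N1C(=O)/C(=C/c2ccc(O)c(Cl)c2)S/C1=N\CCCF`: 3.4
- compound 2, `CCC/N=C1\S/C(=C\c2ccc(O)c(Cl)c2)C(=O)N1C1CCS(=O)(=O)CC1`: 2.6

Of the compounds shown here, two have been measured in a physicochemical assay for lipophilicity, read by HPLC, at pH 7.4; a higher number here means a more lipophilic compound, a lower number a more polar compound. In this assay compound 1 gives 3.4, the higher of the two numbers. Compound 2 gives 2.6 in this assay, a value that sits lower than that of compound 1 by a gap beyond the usual scatter. The two differ in more than one place, so no single change can be read from their values.

Compound 3, `Cc1ccccc1N1C(=O)/C(=C/c2ccc(O)c(Cl)c2)S/C1=N\CCO`, has not yet been measured. It differs from compound 1 in one place: hydroxy in place of fluoromethyl on a saturated chain carbon, two bonds along the chain from a double-bonded nitrogen. For the measured compounds named here, no measured pair shows this change, so its effect must be estimated. Trading a fluoromethyl for a hydroxy, with one hydrogen-bond donor and one hydrogen-bond acceptor entering, is expected to move the number in this assay downward, by a step of about a number 1.30 log units lower from compound 1 to compound 3 (beyond the scatter) from compound 1 to compound 3, clearly beyond the scatter. Compound 3 is therefore estimated to give 2.1 in this assay, in a range from 1.6 to 2.6.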

Compound 3, distribution coefficient: 1.9
The estimate for compound 3 lay 0.20 log units above the measured number; measured number inside the range.
By their numbers in this assay, from the lowest: compound 3; then compound 2; then compound 1.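

For the compounds shown here, compound 3 gives the first reading of a single change in this study: with the rest of compound 1 kept, hydroxy in place of fluoromethyl on a saturated chain carbon, two bonds along the chain from a double-bonded nitrogen, gives a large step in this assay, a number 1.50 log units lower from compound 1 to compound 3 (beyond the scatter), which lies beyond the scatter. The earlier values could not show this, as compound 1 and compound 2 differ in more than one place and no single change could be read from them; this position on the chain is now seen to be one where a change of a few atoms moves the number in this assay well beyond the scatter. Nothing available explains the size of this step.

The step also comes from one exchange on one core, so it cannot separate what the departing fluoromethyl contributes from what the entering hydroxy contributes, a question that a methoxy or a plain ethyl at this place would address. As far as these compounds go, how an amine, a carboxylic acid or a longer chain ending in hydroxy would read at the same place remains open.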